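Hydroxybenzamide nitrile series: aryl swap at the phenol ring

The source may report more compounds than this note shows. Statements on the series, on what has been measured and on what is new or still open speak of the compounds shown alone.

Three measured compounds anchor this set. Compound 1 `N#Cc1ccc(NC(=O)c2ccc(Br)cc2O)cc1Cl` carries a bromo and a chloro substituent; in a functional assay on KG-1 cells (Homo sapiens) for cytotoxicity, read by luminescence and CellTiter-Glo, with a stated time of 3 days (on this read-out lower numbers stand for stronger inhibition and higher numbers for weaker inhibition), compound 1 gives 960 nM. Compound 2 `N#Cc1ccc(NC(=O)c2cc(-c3cccnc3)ccc2O)cc1` bears a pyridin-3-yl group on the phenol ring; in this assay compound 2 gives 8330 nM, the highest of the two numbers recorded, and its nearest neighbour is compound 1 with a number lower than that of compound 2 by a margin beyond the scatter. Compound 3 `N#Cc1ccc(NC(=O)c2ccc[nH]c2=O)cc1` sits at a limit of this assay: compound 3 gives > 10000 nM, which is a limit and not a number, so it is not ranked against the others (the limit of > 10000 nM in this assay, at which 1 of the 3 values shown sits).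

The next compound, compound 4 `N#Cc1ccc(NC(=O)c2cc(-c3ccccc3)ccc2O)cc1`, is not yet measured. It differs from compound 2 in one place (phenyl in place of pyridin-3-yl on an aromatic carbon). For the measured compounds named here, no directly comparable pair of measured compounds exists for this change, so its effect in this assay is open. The two aryl groups match in heavy-atom count and differ only in one ring nitrogen and the single hydrogen-bond acceptor it brings; a modest step in either direction, or none beyond the scatter, is the working expectation.

On that basis the estimated step from compound 2 to compound 4 is a 1.9-fold lower number from compound 2 to compound 4 (0.27 log units; within the scatter), and compound 4 is expected to give about 4500 nM in this assay, within a range from 1200 nM to 15000 nM.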

Compound 4, half-maximal inhibitory concentration: 1300 nM
The estimate for compound 4 lay 3.5-fold (0.54 log units) above the measured number; the measured number falls inside the stated range.
By their numbers in this assay, from the lowest: compounds 1 and 4 (each within the scatter of the next); then compound 2. At a limit, above all of these: compound 3.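

Notes on the aryl position: this is the first one-place comparison in the series, and in this assay phenyl in place of pyridin-3-yl gives a 6.4-fold lower number from compound 2 to compound 4 (0.81 log units; beyond the scatter). The position on the aromatic carbon para to a hydroxy group therefore responds to a change of a single ring atom, since the two aryl groups match in heavy-atom count and differ only in the ring nitrogen and its one hydrogen-bond acceptor. Nothing measured for these compounds accounts for the size or direction of this step.

For the compounds shown here, with only two aryl groups at this position, it remains open whether the ring nitrogen counts against activity wherever it stands, as pyridin-4-yl or pyridin-2-yl would test, and whether a phenyl carrying a methoxy group, a carboxylic acid or an aminomethyl group, or a saturated ring such as piperidine, would move the number further in either direction. Going by these compounds alone, it also remains open whether the step carries over to a partner with a chloro group on the nitrile-bearing ring, since no pair in the set tests that combination.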